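Ester chain length and cytotoxicity in a nucleoside series

This account rests on a few compounds, and the source may have more. Where it says the series, first, only, none or still open, it means among the compounds named here.

Compound 1, `CCCCCCCCCCCCCC(=O)O[C@H]1[C@H](O)[C@H](n2ccc(N)nc2=O)O[C@@H]1CO`, gives 0.08 ug/mL in a functional assay on HeLa cells (Homo sapiens) for cytotoxicity, read by cell counting, with a stated time of 48 h; on this read-out higher numbers stand for an effect only at larger amounts of compound and lower numbers for an effect already at smaller amounts. Compound 2, `CC(=O)O[C@H]1[C@H](O)[C@H](n2ccc(N)nc2=O)O[C@@H]1CO`, gives 0.14 ug/mL in this assay.

The two numbers lie within the scatter of each other, so compound 2 cannot be separated from compound 1 on these data. Compound 3, `CCCCCCCCCCC(=O)O[C@H]1[C@H](O)[C@H](n2ccc(N)nc2=O)O[C@@H]1CO`, is not yet measured. It differs from compound 2 by nonyl in place of hydrogen on a saturated chain carbon bound to a carbonyl carbon. Since compound 1 carries a longer chain at the same position and still sits within the scatter of compound 2, no step beyond the scatter is expected from compound 2 to compound 3, a 1.4-fold lower number from compound 2 to compound 3 (0.15 log units; within the scatter). For compound 3 the expected value is 0.1 ug/mL, with a range from 0.04 ug/mL to 0.25 ug/mL.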

Compound 3, concentration for half-maximal effect: 0.04 ug/mL
Estimate against measurement, compound 3: 2.5-fold (0.40 log units) above; measured number inside the range.
By their numbers in this assay, from the lowest: compounds 3, 1 and 2 (each within the scatter of the next, the first and the last beyond it).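

In this assay nonyl in place of hydrogen on a saturated chain carbon bound to a carbonyl carbon gives a 3.5-fold lower number from compound 2 to compound 3 (0.54 log units; beyond the scatter) and so clears the scatter, which the earlier pair did not do. Hydrogen in place of propyl on a saturated chain carbon gives a 2.0-fold lower number from compound 1 to compound 3 (0.30 log units; within the scatter) and stays within the scatter, so these two compounds cannot be told apart. No measurement here bears on the reason for either step. From the compounds shown here alone, it remains open whether butyl in place of nonyl would already give this step, and whether a longer chain would keep the numbers this low.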